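Ethyl for Methyl on the Sulfonamide: Effect on Cytotoxicity

The source may hold more compounds than are shown below. What is called first, only, known or untested is meant among the compounds shown, and "the series" means these compounds.

All three measured compounds were tested in an ADME assay on RAW264.7 cells (Mus musculus) for cytotoxicity, read by MTT assay, with a stated time of 48 h; on this read-out higher numbers stand for weaker inhibition and lower numbers for stronger inhibition. Compound 1 `COc1cc(NC(=O)c2ccc(Cl)c([N+](=O)[O-])c2)ccc1NS(C)(=O)=O` gives only a limit of the assay, > 250000 nM. Compound 2 `CCS(=O)(=O)Nc1ccc(NC(=O)c2ccc(Cl)c([N+](=O)[O-])c2)cc1OC`, in this assay, gives 5660 nM. The difference between them is methyl in place of hydrogen on a saturated chain carbon bound to a sulfonyl sulfur, and the step is an at least 44-fold lower number from compound 1 to compound 2 (1.64 log units; beyond the scatter); its open-ended size arises because compound 1 sits at the limit of > 250000 nM in this assay, at which 1 of the 3 values shown sits.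

Compound 3 `CS(=O)(=O)Nc1ccc(NC(=O)c2cccc(C(F)(F)F)c2)cc1F` gives 32300 nM in this assay, the highest number among the measured compounds. How its core differs from the core of compound 1 is not broken down here.

Compound 4 `CCS(=O)(=O)Nc1ccc(NC(=O)c2cccc(C(F)(F)F)c2)cc1F` has not yet been measured. It differs from compound 3 by methyl in place of hydrogen on a saturated chain carbon bound to a sulfonyl sulfur, the same change that separates compound 1 from compound 2. Resting on the single earlier step of an at least 44-fold lower number from compound 1 to compound 2 (1.64 log units; beyond the scatter), which was large though open-ended, the expected step from compound 3 to compound 4 is an 8.1-fold lower number from compound 3 to compound 4 (0.91 log units; beyond the scatter), a smaller move taken with caution since one example supports it. In this assay compound 4 is estimated at 4000 nM, expected to lie between 600 nM and 25000 nM.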

Compound 4, half-maximal inhibitory concentration: 119000 nM
Estimate against measurement, compound 4: 30-fold (1.47 log units) below, outside the stated range (above it).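

In this assay, methyl in place of hydrogen on a saturated chain carbon bound to a sulfonyl sulfur gives a 3.7-fold higher number from compound 3 to compound 4 (0.57 log units; beyond the scatter). Set beside the earlier step, this shows that the same change moves the number in opposite directions on the two cores, so neither its size nor its direction carries from one core to the other in this series: the same change on two cores in this assay, an at least 44-fold lower number (1.64 log units; beyond the scatter) from compound 1 to compound 2 and a 3.7-fold higher number (0.57 log units; beyond the scatter) from compound 3 to compound 4, at least 160-fold (2.21 log units) apart, beyond the scatter of two such steps What this does not show is which difference between the cores lies behind the reversal, or how large the earlier step truly is, since that step starts from the limit held by compound 1: the limit of > 250000 nM in this assay, at which 1 of the 4 values shown sits.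

Going by these compounds, with only methyl and ethyl on each core, it remains open whether a longer chain bound to the sulfonyl sulfur, such as propyl, would continue either direction. On these data alone, it also remains open which of the groups separating the two cores sets the direction of the step.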